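Swapping 3-methoxyazetidin-1-yl for cyclopropyl on a carbonyl carbon

A few compounds are considered here, and "the series" means these few. Any claim that something is new, unique, unknown or untested is made for them only; others in the source may bear on it.

Compound 1 `CCn1c(-c2cnc(C)nc2)nc2c(N[C@H]3CCN(C(=O)N4CC(OC)C4)C3)ncnc21`: 1.4 L/kg
Compound 2 `CCn1c(-c2cnc(C)nc2)nc2c(O[C@H]3CCN(C(=O)C4CC4)C3)ncnc21`: 0.6 L/kg

In an ADME assay (Canis lupus familiaris, strain Beagle) for pharmacokinetics (on this read-out higher numbers stand for wider distribution into tissues and lower numbers for narrower distribution), compound 1 stands the higher of the two measured compounds at 1.4 L/kg and compound 2 lies lower at 0.6 L/kg with a gap beyond the usual scatter. Compound 3 `CCn1c(-c2cnc(C)nc2)nc2c(N[C@H]3CCN(C(=O)C4CC4)C3)ncnc21` has not yet been measured. It keeps the core of compound 1 and carries cyclopropyl in place of 3-methoxyazetidin-1-yl on a carbonyl carbon. Among the compounds with values here, no measured pair differing in one place shows what such a change does in this assay so the expectation rests on thin ground. The only scale at hand is the gap between the two measured values, and compound 2 at 0.6 L/kg is the sole lower reference. A small downward move that stays within the scatter is therefore expected. The expected move is a 1.4-fold lower number from compound 1 to compound 3 (0.15 log units; within the scatter) and it could plausibly go either way. For compound 3 the estimated value is 1 L/kg with an expected range from 0.55 L/kg to 1.9 L/kg still awaiting measurement.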

Compound 3, volume of distribution: 1.5 L/kg
Compound 3: the middle estimate sits 1.5-fold (0.18 log units) below what was measured, within the range that was stated.
By their numbers in this assay, from the lowest: compound 2; then compounds 1 and 3 (each within the scatter of the next).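

Within the data shown here, putting cyclopropyl in place of 3-methoxyazetidin-1-yl on a carbonyl carbon, whose other neighbour is an amide-type nitrogen in a ring, gives in this assay the first single-place comparison at this position: a 1.1-fold higher number from compound 1 to compound 3 (0.03 log units; within the scatter). The group that leaves has 6 heavy atoms and 1 hydrogen-bond acceptor while the group that enters has 3 heavy atoms and 0 hydrogen-bond acceptors, yet this read-out does not tell the two compounds apart, so at this position it is insensitive to this particular exchange. Nothing measured here accounts for the two groups reading alike.

From the compounds shown here alone, with only these two groups seen on the carbonyl carbon in a single-place step, it stays open whether the same flat reading would hold for an amine, a carboxylic acid or a longer chain there. The step also leaves unsettled what sets apart compound 2 at 0.6 L/kg, which carries cyclopropyl on its carbonyl carbon as well, from compound 3 at 1.5 L/kg.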